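The compounds below may be only part of what the source reports. "The series", "measured", "known", "first", "only" and "open" are said of these compounds alone.

Of the compounds shown here, three have been measured in a functional assay on Caco-2 cells (Homo sapiens), read by fluorescence and BrdU incorporation, with a stated time of 48 h, tested at 25 uM; a lower number here means a stronger effect, a higher number a weaker effect of the compound at the concentration tested. Compound 1 `COc1cc(OC)c(C(=O)/C=C/c2ccccc2SC)c(OC)c1` gives 2.2%. Compound 2 `COc1cccc(/C=C/C(=O)c2c(OC)cc(OC)cc2OC)c1` gives 6%; its core differs from that of compound 1 by 3-methoxyphenyl in place of 2-(methylsulfanyl)phenyl on a double-bonded chain carbon bound to a double-bonded chain carbon, and the step of a number 3.8 percentage points higher from compound 1 to compound 2 (within the scatter) is small. Compound 3 `COc1cc(O)c(C(=O)/C=C/c2ccccc2SC)c(OC)c1` gives 37%; it differs from compound 1 by hydrogen in place of methyl on an oxygen on an aromatic ring, and the step of a number 34.8 percentage points higher from compound 1 to compound 3 (beyond the scatter) is the only large one among these three compounds.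

Compound 4 `COc1cccc(/C=C/C(=O)c2c(O)cc(OC)cc2OC)c1` has not yet been measured in this assay. It differs from compound 2 by hydrogen in place of methyl on an oxygen on an aromatic ring, the same kind of change as that from compound 1 to compound 3, and the surroundings of the place read the same in both pairs. Within the data shown here, only one such step has been seen, so the expectation rests on a single pair. Compound 4 is expected to step by a number 34 percentage points higher from compound 2 to compound 4 (beyond the scatter) because the analogous step a number 34.8 percentage points higher from compound 1 to compound 3 (beyond the scatter) was large and because, close to compound 1, compound 2 gives 6%. Compound 4 is therefore estimated at 40% in this assay, with a range from 20% to 65%.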

Compound 4, a percentage reported as activity, at one concentration (the size of the read-out at that concentration, not a potency): 34%
Estimate against measurement, compound 4: 6 percentage points above; the measured number falls inside the stated range.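

In this assay, exchanging methoxy for hydroxy on the aromatic ring of compound 2 gives a number 28 percentage points higher from compound 2 to compound 4 (beyond the scatter). Set beside the same exchange on the core of compound 1, the two steps cannot be told apart: the same change on two cores in this assay, a number 34.8 percentage points higher (beyond the scatter) from compound 1 to compound 3 and a number 28 percentage points higher (beyond the scatter) from compound 2 to compound 4, 6.8 percentage points apart, within the scatter of two such steps. Among these compounds, the exchange therefore carried over between these two cores in direction and, within the scatter, in size, but this rests on only two pairs and does not show that it would carry over to other cores, nor does it explain why the number rises.

The compounds shown leave open what other groups on that aromatic ring would do, for instance an amine in place of the hydroxy group, or an ethoxy group or a longer chain on the oxygen in place of methyl. They also leave open how the hydroxy and methoxy compounds compare in potency, since this assay reports activity at a single concentration.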